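The source may hold more compounds than are shown below. What is called first, only, known or untested is meant among the compounds shown, and "the series" means these compounds.

Measured so far in an ADME assay on J774.A1 cells (Mus musculus) for cytotoxicity, read by MTT assay; a higher number here means that more compound is tolerated, a lower number that less compound is tolerated:
compound 1 `CC(CCn1ccnc1)Oc1ccc(C(F)(F)F)cc1` gives 7.5 ug/mL.
compound 2 `CC(CCn1ccnc1)Oc1ccccc1[N+](=O)[O-]` gives > 100 ug/mL.
compound 3 `FC(F)(F)c1ccc(OC(CCn2ccnc2)COc2ccccc2)cc1` gives 17.9 ug/mL.

For compound 2 the figure is a limit of this assay, not a number; it is one of the values at the limit of > 100 ug/mL in this assay, at which 1 of the 3 values shown sits.

Compound 3 differs from compound 1 by phenoxy in place of hydrogen on a saturated chain carbon, two bonds along the chain from an oxygen on an aromatic ring. That change gave a 2.4-fold higher number from compound 1 to compound 3 (0.38 log units; beyond the scatter). The difference between the cores of compound 1 and compound 2 is not broken down here.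

Compound 4 `O=[N+]([O-])c1ccccc1OC(CCn1ccnc1)COc1ccccc1` is not yet measured in this assay. It differs from compound 2 by phenoxy in place of hydrogen on a saturated chain carbon, two bonds along the chain from an oxygen on an aromatic ring, the same change as from compound 1 to compound 3, at the same place. A step of the same kind is expected, a step that the limit leaves unreadable from compound 2 to compound 4, resting on the step of a 2.4-fold higher number from compound 1 to compound 3 (0.38 log units; beyond the scatter). Since compound 2 already sits at a limit, compound 4 is estimated at 180 ug/mL in this assay, between 60 ug/mL and 500 ug/mL, and most likely reported again only as a limit.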

Compound 4, half-maximal cytotoxic concentration: 36.2 ug/mL
The estimate for compound 4 lay 5.0-fold (0.70 log units) above the measured number; measured number below the stated range.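

In this assay the phenoxy change gives an at least 2.7-fold lower number from compound 2 to compound 4 (0.44 log units; beyond the scatter), so it does not carry over in direction from one core to the other in this series: the same change on two cores in this assay, a 2.4-fold higher number (0.38 log units; beyond the scatter) from compound 1 to compound 3 and an at least 2.7-fold lower number (0.44 log units; beyond the scatter) from compound 2 to compound 4, at least 6.5-fold (0.81 log units) apart, beyond the scatter of two such steps.
For compound 2 the entry > 100 ug/mL is a limit of the assay and not a number, so this step has a lower bound only.
These two pairs show that the outcome depends on the core, but they give no rule for other cores and do not tell which difference between the cores matters.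

Open, from the compounds shown here alone, is how the change behaves on a core carrying a nitrile or an amine in place of trifluoromethyl or nitro. Also open, going by these compounds, is whether benzyloxy or a longer chain in place of phenoxy would follow the step to compound 3 or the step to compound 4.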